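The source may hold more compounds than are shown below. What is called first, only, known or untested is meant among the compounds shown, and "the series" means these compounds.

Three compounds share one core and differ only in what hangs from the amine at the end of the chain. Compound 1 `OC1(CNCc2ccccc2)CCN(CCCc2c[nH]c3ccc(-n4cnnc4)cc23)CC1` carries a benzyl group there; in an assay on CHO cells with 5-hydroxytryptamine receptor 1D (Homo sapiens) as the target (a higher number here means a weaker inhibitor, a lower number a stronger inhibitor), compound 1 gives 0.45 nM. Compound 2 `CC(C)(C)OC(=O)NCC1(O)CCN(CCCc2c[nH]c3ccc(-n4cnnc4)cc23)CC1` carries a tert-butoxycarbonyl group instead, and in this assay compound 2 gives 21 nM. Compound 3 `CC(=O)Nc1ccc(CNCC2(O)CCN(CCCc3c[nH]c4ccc(-n5cnnc5)cc34)CC2)cc1` keeps the benzyl but adds an acetamido group to its ring, and in this assay compound 3 gives 11 nM. Compound 1 thus stands lowest of the three: there is a 47-fold higher number from compound 1 to compound 2 (1.67 log units; beyond the scatter) and a 24-fold higher number from compound 1 to compound 3 (1.39 log units; beyond the scatter), while between the other two there is only a 1.9-fold lower number from compound 2 to compound 3 (0.28 log units; within the scatter).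

Compound 4 `CN(CC1CCCCC1)CC1(O)CCN(CCCc2c[nH]c3ccc(-n4cnnc4)cc23)CC1` changes the same place in another way: (cyclohexylmethyl)(methyl)amino in place of benzylamino on a saturated chain carbon bound to a saturated ring carbon. Both measured steps away from compound 1 altered this same end of the molecule and both made the number much higher, yet neither swapped the aromatic ring for a non-aromatic one or removed the donor hydrogen, so they do not speak directly to this change. A weakening is expected, but a smaller one: the estimate for compound 4 is 5 nM, with a range from 1 nM to 25 nM, which means an expected step of an 11-fold higher number from compound 1 to compound 4 (1.05 log units; beyond the scatter).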

Compound 4, half-maximal inhibitory concentration: 1.2 nM
Estimate against measurement, compound 4: 4.2-fold (0.62 log units) above, within the range that was stated.
By their numbers in this assay, from the lowest: compound 1; then compound 4; then compounds 3 and 2 (each within the scatter of the next).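

In this assay a 2.7-fold higher number from compound 1 to compound 4 (0.43 log units; beyond the scatter) is a modest change, even though it replaces the aromatic ring of the benzyl group with a non-aromatic ring and leaves no donor hydrogen on that nitrogen. Going by these compounds alone, this end of the molecule therefore tolerates more than the earlier compounds suggested, and a low number needs neither that aromatic ring nor that hydrogen, at least in this one combination. Compound 4 also stands well clear of the other two, with a 9.2-fold lower number from compound 3 to compound 4 (0.96 log units; beyond the scatter) and an 18-fold lower number from compound 2 to compound 4 (1.24 log units; beyond the scatter) in the same assay, yet no measurement shown here explains why these groups differ so much.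

The step from compound 1 to compound 4 combines several changes, so its size cannot be divided between the ring and the added methyl; benzyl(methyl)amino or (cyclohexylmethyl)amino would each carry only one of them. From the compounds shown here alone, it also remains open how a simple methylamino group with no ring, or a pyridinylmethyl group with a nitrogen in the ring, would compare at this position.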